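Swapping the Aryl Group on the Hydrazone of a Urea Series

A few compounds are considered here, and "the series" means these few. Any claim that something is new, unique, unknown or untested is made for them only; others in the source may bear on it.

Measured compounds:
Compound 1, `CN(C)CCn1cnnc1-c1cc(Oc2ccc(NC(=O)N/N=C/c3c(Cl)cccc3Cl)cc2F)ccn1`, gives 280 nM in a functional assay on HT-29 cells (Homo sapiens) for cytotoxicity, read by MTT assay, with a stated time of 72 h; on this read-out higher numbers stand for weaker inhibition and lower numbers for stronger inhibition.
Compound 2, `COc1ccc(/C=N/NC(=O)Nc2ccc(Oc3ccnc(-c4nncn4CCN(C)C)c3)c(F)c2)c(OC)c1OC`, gives 3970 nM in this assay.
Compound 3, `CN(C)CCn1cnnc1-c1cc(Oc2ccc(NC(=O)N/N=C/c3ccccc3O[N+](=O)[O-])cc2F)ccn1`, gives 950 nM in this assay.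

All three share one core and differ only in the aryl group on a carbon with a double bond to nitrogen. Compound 3 stands second highest of the three numbers: the step from the dichloro compound is a 3.4-fold higher number from compound 1 to compound 3 (0.53 log units; beyond the scatter), while the step from the trimethoxy compound is a 4.2-fold lower number from compound 2 to compound 3 (0.62 log units; beyond the scatter). Among the measured compounds shown here, the one large step seen is a 14-fold higher number from compound 1 to compound 2 (1.15 log units; beyond the scatter).

Compound 4, `CN(C)CCn1cnnc1-c1cc(Oc2ccc(NC(=O)N/N=C/c3ccc(O)c(O)c3)cc2F)ccn1`, has not yet been measured. The change is 3,4-dihydroxyphenyl in place of 2-(nitrooxy)phenyl on a carbon with a double bond to nitrogen. For the measured compounds named here, no measured step introduces a ring bearing hydroxyl groups, so the expectation rests on analogy: the ring in compound 2 also carries several oxygen-linked substituents and gave the highest number, with the step being a 14-fold higher number from compound 1 to compound 2 (1.15 log units; beyond the scatter). Compound 4 is therefore estimated to land between compound 3 and compound 2, at about 2000 nM, with a likely range from 600 nM to 7000 nM. That estimate for compound 4 means an expected step of a 2.1-fold higher number from compound 3 to compound 4 (0.32 log units; beyond the scatter), a weakening beyond the scatter.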

Compound 4, half-maximal inhibitory concentration: 1890 nM
Estimate against measurement, compound 4: 1.1-fold (0.02 log units) above; measured number inside the range.
By their numbers in this assay, from the lowest: compound 1; then compounds 3 and 4 (each within the scatter of the next); then compound 2.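

In (this assay), the 3,4-dihydroxyphenyl ring on the carbon with a double bond to nitrogen cannot be told apart from 2-(nitrooxy)phenyl (a 2.0-fold higher number from compound 3 to compound 4 (0.30 log units; within the scatter)), so this exchange, which brings hydrogen-bond donors onto the ring, gives no readable change in the number. The same ring does separate from the other two, with (a 2.1-fold lower number from compound 2 to compound 4 (0.32 log units; beyond the scatter)) against 2,3,4-trimethoxyphenyl and (a 6.8-fold higher number from compound 1 to compound 4 (0.83 log units; beyond the scatter)) against 2,6-dichlorophenyl, and so all three oxygen-bearing rings now give higher numbers than the dichloro ring, with none of the four compounds going against that pattern. Nothing measured here explains these differences.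

The compounds shown leave open whether the two hydroxyl groups matter in themselves, since no pair here differs only by a hydroxyl group exchanged for a methoxy group. They also leave open how this position responds to a ring carrying a single chlorine or a single hydroxyl group, or to a ring bearing an amine or a carboxylic acid.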